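Variation on the amide of a shared core

This account rests on a few compounds, and the source may have more. Where it says the series, first, only, none or still open, it means among the compounds named here.

Compound 1 `C#CC(C)OC(=O)c1ccc(C(CC)(CC)c2ccc(OCCC(O)(CC)CC)c(C)c2)n1CC`: 2650 nM
Compound 2 `CCn1c(C(=O)Nc2ccc(OC(F)(F)F)cc2)ccc1C(CC)(CC)c1ccc(OCCC(O)(CC)CC)c(C)c1`: > 10000 nM

Compound 1 `C#CC(C)OC(=O)c1ccc(C(CC)(CC)c2ccc(OCCC(O)(CC)CC)c(C)c2)n1CC` gives 2650 nM in an assay on cells for agonist activity at vitamin D3 receptor (Homo sapiens), with a stated time of 96 h; on this read-out lower numbers stand for an effect already at smaller amounts and higher numbers for an effect only at larger amounts of compound. For compound 2 `CCn1c(C(=O)Nc2ccc(OC(F)(F)F)cc2)ccc1C(CC)(CC)c1ccc(OCCC(O)(CC)CC)c(C)c1` the reading is a limit, > 10000 nM, so compound 2 stands at the edge of what this assay reports (the limit of > 10000 nM in this assay, at which 1 of the 2 values shown sits). For the measured compounds named here, the only measured step at this carbonyl carbon is an at least 3.7-fold higher number from compound 1 to compound 2 (0.57 log units; beyond the scatter). Compound 3 `CCn1c(C(=O)N(C)CC(=O)O)ccc1C(CC)(CC)c1ccc(OCCC(O)(CC)CC)c(C)c1` differs from compound 2 by (carboxymethyl)(methyl)amino in place of (4-(trifluoromethoxy)phenyl)amino on a carbonyl carbon. Going by the values given here, no measured step shows this change, and the start is a limit. Compound 3 is expected near that limit, an at least 1.2-fold lower number from compound 2 to compound 3 (0.09 log units; that floor lies within the scatter), estimated at 8000 nM (range 1500 nM to 30000 nM).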

Compound 3, half-maximal effective concentration: 89 nM
The estimate for compound 3 lay 90-fold (1.95 log units) above the measured number, and the stated range ends above it.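

At this carbonyl carbon the change can also run the other way in this assay: (carboxymethyl)(methyl)amino gives an at least 110-fold lower number from compound 2 to compound 3 (2.05 log units; beyond the scatter), and a 30-fold lower number from compound 1 to compound 3 (1.47 log units; beyond the scatter). The reading for compound 2 is a limit, so the first of these steps is only a floor: the limit of > 10000 nM in this assay, at which 1 of the 3 values shown sits.

The compounds shown leave open which part of the entering group carries this difference. A methyl ester in place of the carboxylic acid, a longer chain such as carboxyethyl, or a hydrogen in place of the methyl on nitrogen would separate these parts.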